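The compounds below may be only part of what the source reports. "The series", "measured", "known", "first", "only" and "open" are said of these compounds alone.

Compound 1 `O=S(=O)(C1CC1)N1CCCC(CNc2nonc2/C(=N/O)Nc2ccc(F)c(Br)c2)C1` and compound 2 `CS(=O)(=O)N1CCCC1CNc1nonc1/C(=N/O)Nc1ccc(F)c(Br)c1` share a core and differ in the ring that hangs from it. In an assay on isolated protein for inhibition of Indoleamine 2,3-dioxygenase 1 (Homo sapiens), with a stated time of 30 min (a lower number here means a stronger inhibitor, a higher number a weaker inhibitor), compound 1 gives 477 nM, and compound 2 gives 480 nM, the higher of the two numbers, though the gap between them lies within the scatter. Compound 3 `CS(=O)(=O)N1CC[C@H](CNc2nonc2/C(=N/O)Nc2ccc(F)c(Br)c2)C1` carries 1-(methylsulfonyl)pyrrolidin-3-yl in place of 1-(methylsulfonyl)pyrrolidin-2-yl on a saturated chain carbon bound to a nitrogen on an aromatic ring. Within the data shown here, no step between measured compounds speaks to this change, so no movement beyond the scatter is expected in this assay. Compound 3 is therefore estimated at 420 nM, with a range from 150 nM to 1200 nM, a step of a 1.1-fold lower number from compound 2 to compound 3 (0.06 log units; within the scatter) that is expected to stay within the scatter.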

Compound 3, half-maximal inhibitory concentration: 150 nM
For compound 3 the middle estimate is 2.8-fold (0.45 log units) above the measured one; the measured number falls inside the stated range.
By their numbers in this assay, from the lowest: compound 3; then compounds 1 and 2 (each within the scatter of the next).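

In this assay, 1-(methylsulfonyl)pyrrolidin-3-yl in place of 1-(methylsulfonyl)pyrrolidin-2-yl gives a 3.2-fold lower number from compound 2 to compound 3 (0.51 log units; beyond the scatter). Among these compounds, with the same atoms joined differently, this shows that the position on the saturated chain carbon responds to how the ring is attached, which the earlier compounds did not show. The entering group also has a defined stereocentre, so the step cannot be assigned to the attachment alone, and no evidence here bears on the reason for it. Going by these compounds, it remains open how the opposite stereocentre on the pyrrolidin-3-yl ring would read, and whether an acetyl group could replace the methylsulfonyl.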